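Trifluoromethyl to hydrogen on the phenyl: compound 3 to compound 4

The compounds below may be only part of what the source reports. "The series", "measured", "known", "first", "only" and "open" are said of these compounds alone.

Among the compounds with values here, compound 3 `FC(F)(F)c1ccccc1Cn1nnc2c(NC3CC3)nc(-c3ccccc3)nc21` has the lowest number of the three measured so far in an assay on isolated protein for binding affinity to adenosine receptor A1 (Bos taurus) (a lower number here means a stronger inhibitor, a higher number a weaker inhibitor), where compound 3 gives 7800000 nM. Compound 1 `Fc1ccccc1Cn1nnc2c(NC3CC3)nc(-c3ccccc3)nc21` sits nearest, with compound 1 giving 15000000 nM, a gap within the scatter; compound 2 `OCCCNc1nc(-c2ccccc2)nc2c1nnn2Cc1ccccc1` is furthest, with compound 2 giving 21400000 nM, a gap beyond the scatter. Within the data shown here, the one step made through a single change is a 1.9-fold lower number from compound 1 to compound 3 (0.28 log units; within the scatter). Compound 4 `c1ccc(Cn2nnc3c(NC4CC4)nc(-c4ccccc4)nc32)cc1` differs from compound 3 by hydrogen in place of trifluoromethyl on an aromatic carbon, ortho to a large group; cut one bond further out, the change reads 2-(trifluoromethyl)phenyl to phenyl. Among the measured compounds shown here, only the step from compound 1 to compound 3 bears on this, since it alters the same aromatic carbon, and that step stayed within the scatter. A swap of one substituent for another at this carbon having moved the number little, removal of the group is expected to leave compound 4 within the scatter of compound 3, with the step of a 1.5-fold higher number from compound 3 to compound 4 (0.19 log units; within the scatter) expected to be small. Compound 4 is therefore estimated at 12000000 nM, in the range 5000000 nM to 30000000 nM.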

Compound 4, inhibition constant: 11000000 nM
Beside the measured number, compound 4's estimate is 1.1-fold (0.04 log units) above it; the range from low to high includes it.
By their numbers in this assay, from the lowest: compounds 3, 4, 1 and 2 (each within the scatter of the next, the first and the last beyond it).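

Removing the substituent gives this position its unsubstituted reference in this assay: a 1.4-fold higher number from compound 3 to compound 4 (0.15 log units; within the scatter) and a 1.4-fold lower number from compound 1 to compound 4 (0.13 log units; within the scatter). Together with the earlier step between fluoro and trifluoromethyl, this places hydrogen, fluoro and trifluoromethyl on this aromatic carbon, ortho to a large group, all within the scatter of one another, and no separation among the three can be read. Within the data shown here, compound 4 also gives the first single-change reading on the nitrogen, where a 1.9-fold lower number from compound 2 to compound 4 (0.29 log units; within the scatter), and no supporting measurement bears on these results.

As far as these compounds go, whether an amine or a carboxylic acid on this aromatic carbon would give a step beyond the scatter remains open. Also open, from the compounds shown here alone, is whether a longer chain or an amide on the nitrogen would separate from cyclopropyl and 3-hydroxypropyl.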